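The source may hold more compounds than are shown below. What is called first, only, known or untested is meant among the compounds shown, and "the series" means these compounds.

Measured in an ADME assay on microsomes from liver (Homo sapiens) for metabolic stability; on this read-out lower numbers stand for a shorter-lived compound and higher numbers for a longer-lived compound:

compound 1 `CCCNC(=O)C1CCN(C(=O)c2cc3ccsc3n2Cc2ccc(OC)cc2)CC1`, which gives 0.068 h
compound 2 `CCCNC(=O)C1CCN(C(=O)c2cc3cc(Br)ccc3n2Cc2ccc(OC)cc2)CC1`, which gives 0.0657 h
compound 3 `CCCNC(=O)C1CCN(C(=O)c2cc3ccccc3n2Cc2ccc(OC)cc2)CC1`, which gives 0.0443 h

The difference between the core of compound 1 and the core of compound 3 is not broken down here. From compound 3 to compound 2 the change is bromo in place of hydrogen on an aromatic carbon, and this step gave a 1.5-fold higher number from compound 3 to compound 2 (0.17 log units; within the scatter). Compound 4 `CCCNC(=O)C1CCN(C(=O)c2cc3cc(Br)sc3n2Cc2ccc(OC)cc2)CC1` is not yet measured in this assay. From compound 1 to compound 4 the change is bromo in place of hydrogen on an aromatic carbon, the same kind of change, but the place differs: in compound 2 the bromo sits on a six-membered aromatic ring of carbon only, meta to a fused ring and para to a fused ring, while in compound 4 it sits on a five-membered aromatic ring with one sulfur, next to the ring sulfur. The step from compound 1 to compound 4 is expected to be a 1.2-fold higher number from compound 1 to compound 4 (0.07 log units; within the scatter), resting on the earlier step of a 1.5-fold higher number from compound 3 to compound 2 (0.17 log units; within the scatter). Compound 4 is therefore estimated at 0.08 h, between 0.04 h and 0.16 h.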

Compound 4, half-life: 0.127 h
Compound 4: middle estimate off by 1.6-fold (0.20 log units), on the low side; the measured number falls inside the stated range.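

In this assay, bromo in place of hydrogen on an aromatic carbon gives a 1.9-fold higher number from compound 1 to compound 4 (0.27 log units; within the scatter). Set beside the same change on the other core, the two steps cannot be told apart, so the change carries across these two cores as far as this read-out can show: the same change on two cores in this assay, a 1.5-fold higher number (0.17 log units; within the scatter) from compound 3 to compound 2 and a 1.9-fold higher number (0.27 log units; within the scatter) from compound 1 to compound 4, 1.3-fold (0.10 log units) apart, within the scatter of two such steps. This does not show that bromo itself lengthens half-life, since each step lies within the scatter, and two pairs, with bromo in a different place in each, support no rule for other cores.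

The compounds shown leave open whether chloro or a nitrile in the same place would read alike. They also leave open whether the comparison holds with a longer chain on the amide.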